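The source may report more compounds than this note shows. Statements on the series, on what has been measured and on what is new or still open speak of the compounds shown alone.

In a functional assay on U-251 cells (Homo sapiens) for antiproliferative activity, read by MTT assay, with a stated time of 48 h (on this read-out higher numbers stand for weaker inhibition and lower numbers for stronger inhibition), compound 1 `COc1cc(-c2cccc3nc(-c4ccc(Br)cc4)oc23)cc(OC)c1OC` gives > 25000 nM, which is a limit of the assay and not a number. Among the compounds with values here, compound 2 `COc1cc(-c2cccc3nc(-c4ccc(C)cc4)oc23)cc(OC)c1OC` gives 3200 nM, the only true number available. Within the data shown here, the one measured step, an at least 7.8-fold lower number from compound 1 to compound 2 (0.89 log units; beyond the scatter), puts methyl in place of bromo on an aromatic carbon and lies beyond the scatter. Its size rests on (the limit of > 25000 nM in this assay, at which 1 of the 2 values shown sits).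

Compound 3 `COc1cc(-c2cccc3nc(-c4cccc(O)c4)oc23)cc(OC)c1OC` departs from compound 2 at a different level: 3-hydroxyphenyl in place of 4-methylphenyl on an aromatic carbon. Here 3-hydroxyphenyl stands in place of 4-methylphenyl on an aromatic carbon of the five-membered aromatic ring, next to the ring nitrogen and the ring oxygen. Among the measured compounds shown here, the earlier step changed only one group on the aromatic carbon, and no compound with a hydroxy group has been measured, so it bears on this change only loosely and sets no direction. It does show that a single swap can move this assay appreciably, which argues for a wide range. The expected change is a 1.4-fold higher number from compound 2 to compound 3 (0.15 log units; within the scatter), with no firm shift beyond the scatter foreseen. Compound 3 is estimated at 4500 nM, with an expected range from 1200 nM to 18000 nM.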

Compound 3, half-maximal inhibitory concentration: 5500 nM
Compound 3: middle estimate off by 1.2-fold (0.09 log units), on the low side, within the range that was stated.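

In this assay, the swap at this aromatic carbon of the five-membered ring gives a 1.7-fold higher number from compound 2 to compound 3 (0.24 log units; within the scatter), so 3-hydroxyphenyl and 4-methylphenyl cannot be told apart here, even though the first carries a hydrogen-bond donor and acceptor and the second carries neither. The earlier compounds shown here showed only that this position responds to a change from bromo to methyl on the phenyl ring; compound 3 adds that a second, quite different group can sit here with no read-out difference from compound 2. The step of an at least 4.5-fold lower number from compound 1 to compound 3 (0.65 log units; beyond the scatter) puts 3-hydroxyphenyl in place of 4-bromophenyl, so compound 1 now stands apart from both other compounds, but it sits at a limit of the assay and not at a number, and the true size of this step stays unknown: the limit of > 25000 nM in this assay, at which 1 of the 3 values shown sits.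

The hydroxy and methyl groups also sit at different places on the phenyl ring, so the compounds shown do not separate the identity of the group from its place, as 4-hydroxyphenyl or 3-methylphenyl would. Also open, as far as these compounds go, is how this assay responds to an amine or a carboxylic acid on that ring, or to a longer chain in place of the methyl group.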